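Working notes: from compound 3 to compound 4

The source may hold more compounds than are shown below. What is called first, only, known or untested is meant among the compounds shown, and "the series" means these compounds.

- compound 1 `C[C@@H](Oc1cc2oc(=O)n(CCC(=O)O)c2cc1Cl)c1ccc(F)cn1`: 1.98
- compound 2 `C[C@@H](Oc1cc2oc(=O)n(CCC(=O)O)c2cc1Cl)c1ccc(Cl)cn1`: 2.65
- compound 3 `C[C@@H](Oc1cc2oc(=O)n(CCC(=O)O)c2cc1Cl)c1ncco1`: 1.11

In a physicochemical assay for lipophilicity, read by HPLC, at pH 7.4 (on this read-out lower numbers stand for lower lipophilicity and higher numbers for higher lipophilicity), compound 3 stands lowest of the three at 1.11. Compound 4 `Cc1ccnc([C@@H](C)Oc2cc3oc(=O)n(CCC(=O)O)c3cc2Cl)c1` is not yet measured. It has 4-methylpyridin-2-yl in place of 1,3-oxazol-2-yl on a saturated chain carbon bound to an oxygen on an aromatic ring and a saturated chain carbon.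

Two measured steps make the same exchange in the opposite sense, with 1,3-oxazol-2-yl entering and a pyridinyl group leaving: a number 0.87 log units lower from compound 1 to compound 3 (beyond the scatter) and a number 1.54 log units lower from compound 2 to compound 3 (beyond the scatter). Chloro in place of fluoro gives a number 0.67 log units higher from compound 1 to compound 2 (beyond the scatter), so the two pyridinyl groups already differ beyond the scatter. For the measured compounds named here, no measured compound carries 4-methylpyridin-2-yl, which leaves the size of the reversed step uncertain.

A rise of modest to large size is therefore expected in this assay. The expected step is a number 1.09 log units higher from compound 3 to compound 4 (beyond the scatter). Compound 4 is estimated at 2.2, with an expected range of 1.7 to 2.7.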

Compound 4, distribution coefficient: 2.15
The estimate for compound 4 lay 0.05 log units above the measured number, within the range that was stated.
By their numbers in this assay, from the lowest: compound 3; then compounds 1 and 4 (each within the scatter of the next); then compound 2.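

In this assay, for the compounds shown here, a methyl-bearing pyridinyl group on the saturated chain carbon now adds to the exchanges read at this position: 4-methylpyridin-2-yl in place of 1,3-oxazol-2-yl gives a number 1.04 log units higher from compound 3 to compound 4 (beyond the scatter) and so reverses the direction of the earlier steps that brought the oxazolyl group in. Among the pyridinyl groups, 4-methylpyridin-2-yl in place of 5-chloropyridin-2-yl gives a number 0.50 log units lower from compound 2 to compound 4 (beyond the scatter) in this read-out, while in place of 5-fluoropyridin-2-yl it gives a number 0.17 log units higher from compound 1 to compound 4 (within the scatter) and so cannot be told apart from the fluoro group here. Nothing in hand accounts for any of these steps.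

Open, from the compounds shown here alone, is how an unsubstituted pyridin-2-yl group, or a pyridin-2-yl group carrying a methoxy group or an amine, would read at this position.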